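Trimming the Cyclobutyl to Methyl on the Shared Core

The source may report more compounds than this note shows. Statements on the series, on what has been measured and on what is new or still open speak of the compounds shown alone.

The pair measured so far shares one core, carried by compound 2 `CCCCOC(=O)NS(=O)(=O)c1ccc(CCC)cc1-c1ccc(Cn2c(C3CCC3)nc3ccccc32)cc1` and compound 1 `CCCCOC(=O)NS(=O)(=O)c1ccc(CCC)cc1-c1ccc(Cn2c(CC(C)C)nc3ccccc32)cc1`. In an assay on membranes from HEK293 cells for displacement of a labelled ligand from Type-2 angiotensin II receptor (Homo sapiens), read by radioligand binding (a higher number here means a weaker inhibitor, a lower number a stronger inhibitor), compound 2 gives 12 nM and compound 1 gives 19 nM. Among the compounds with values here, compound 2 has the lowest of the two numbers, yet the only step among them, a 1.6-fold lower number from compound 1 to compound 2 (0.20 log units; within the scatter), lies within the scatter, so the two compounds cannot be ranked against each other.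

Compound 3 `CCCCOC(=O)NS(=O)(=O)c1ccc(CCC)cc1-c1ccc(Cn2c(C)nc3ccccc32)cc1` has not yet been measured. It differs from compound 2 by methyl in place of cyclobutyl on an aromatic carbon; the group sits on an aromatic carbon of a five-membered aromatic ring with 2 nitrogen, part of a fused or bridged system of two rings, next to the ring atom that bears a large group.

Within the data shown here, no measured step bears directly on this change. Among the measured compounds shown here, the one step at hand, from compound 1 to compound 2, swapped isobutyl for cyclobutyl and stayed within the scatter, and it says nothing about a shrink to methyl. Compound 3 is therefore expected to weaken modestly in this assay, a 3.3-fold higher number from compound 2 to compound 3 (0.52 log units; beyond the scatter), with a wide range, estimated at 40 nM from 12 nM to 130 nM.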

Compound 3, inhibition constant: 9.4 nM
Compound 3: middle estimate off by 4.3-fold (0.63 log units), on the high side; measured number outside the range, below it.
By their numbers in this assay, from the lowest: compounds 3, 2 and 1 (each within the scatter of the next, the first and the last beyond it).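

In this assay, cutting the cyclobutyl down to methyl, a 1.3-fold lower number from compound 2 to compound 3 (0.11 log units; within the scatter), leaves compound 2 and compound 3 indistinguishable, so on this aromatic carbon between two ring nitrogen atoms, the four-membered ring is not needed to keep the number where compound 2 has it. Set against the isobutyl of compound 1, the same methyl gives the first step in this short series to pass the scatter, though only modestly: a 2.0-fold lower number from compound 1 to compound 3 (0.31 log units; beyond the scatter). The position therefore accepts a single carbon as readily as a four-carbon ring, and among these three compounds the only separation that can be read is between methyl and isobutyl, while nothing available explains these numbers.

What the compounds shown leave open is how far this tolerance extends, since the series holds only small groups made of carbon and hydrogen, and neither bare hydrogen nor an amine, a methoxy group or a phenyl ring on this carbon appears among them. On these data alone, it also remains open whether a longer straight chain, such as n-butyl, would sit with methyl and cyclobutyl or with isobutyl.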